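Solubility series: aryl swap on the chalcone arm

The source may hold more compounds than are shown below. What is called first, only, known or untested is meant among the compounds shown, and "the series" means these compounds.

Within the data shown here, compound 3 `COc1ccc(/C=C/C(=O)c2ccc(NC(=O)CN3CCN(c4cc5c(cc4F)c(=O)c(C(=O)O)cn5C4CC4)CC3)cc2)cc1OC` gives 0.75 ug/mL in a physicochemical assay for solubility, at pH 6.9 (a higher number here means a more soluble compound, a lower number a less soluble compound), the lowest of the three numbers so far. Compound 1 `O=C(CN1CCN(c2cc3c(cc2F)c(=O)c(C(=O)O)cn3C2CC2)CC1)Nc1ccc(C(=O)/C=C/c2ccccc2)cc1` gives 2.73 ug/mL in this assay and compound 2 `O=C(CN1CCN(c2cc3c(cc2F)c(=O)c(C(=O)O)cn3C2CC2)CC1)Nc1ccc(C(=O)/C=C/c2ccc(Cl)cc2)cc1` gives 2.77 ug/mL in this assay; the step of a 1.0-fold higher number from compound 1 to compound 2 (0.01 log units; within the scatter) shows no change. The steps of a 3.6-fold lower number from compound 1 to compound 3 (0.56 log units; beyond the scatter) and a 3.7-fold lower number from compound 2 to compound 3 (0.57 log units; beyond the scatter) are the only ones that bear on the next change. Compound 4 `Cc1ccc(/C=C/C(=O)c2ccc(NC(=O)CN3CCN(c4cc5c(cc4F)c(=O)c(C(=O)O)cn5C4CC4)CC3)cc2)c(C)c1` carries 2,4-dimethylphenyl in place of 3,4-dimethoxyphenyl on a double-bonded chain carbon bound to a double-bonded chain carbon. Among the measured compounds shown here, this removes the group that went with the lower number, while a methyl addition has no measured precedent; a recovery toward compounds 1 and 2 is expected, but not a full one. The step of a 2.4-fold higher number from compound 3 to compound 4 (0.38 log units; beyond the scatter) is therefore expected as a modest rise. Compound 4 is expected at 1.8 ug/mL, with a range from 0.7 ug/mL to 4.5 ug/mL.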

Compound 4, solubility: 2.12 ug/mL
Beside the measured number, compound 4's estimate is 1.2-fold (0.07 log units) below it, and the stated range covers the measured number.
By their numbers in this assay, from the lowest: compound 3; then compounds 4, 1 and 2 (each within the scatter of the next).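

In this assay, 2,4-dimethylphenyl in place of 3,4-dimethoxyphenyl gives a 2.8-fold higher number from compound 3 to compound 4 (0.45 log units; beyond the scatter) at this double-bonded chain carbon, so a disubstituted aryl group here need not bring the low number of compound 3. Among these compounds, the comparisons with phenyl and 4-chlorophenyl give a 1.3-fold lower number from compound 1 to compound 4 (0.11 log units; within the scatter) and a 1.3-fold lower number from compound 2 to compound 4 (0.12 log units; within the scatter), which leaves 3,4-dimethoxyphenyl as the only aryl group of the four that stands apart. Nothing available explains this difference.

On these data alone, whether one methoxy group alone goes with the lower number remains open, as does how an amine or a carboxylic acid on this aryl ring would read in this assay at this pH.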